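Swapping methoxy for fluoro on an indole-type core

This account rests on a few compounds, and the source may have more. Where it says the series, first, only, none or still open, it means among the compounds named here.

Four compounds built on one shared core are compared here. Compound 1 `COc1ccc2[nH]c(-c3nc(-c4ccc(Cl)cc4)no3)cc2c1` is the reference point; in a functional assay on COLO 320 cells (Homo sapiens) for antiproliferative activity, read by WST assay, with a stated time of 72 h (on this read-out lower numbers stand for stronger inhibition and higher numbers for weaker inhibition), compound 1 gives 12800 nM. Compound 2 `Fc1ccc2[nH]c(-c3nc(-c4ccc(Cl)cc4)no3)cc2c1` carries the change (fluoro in place of methoxy on an aromatic carbon). Compound 2 reaches only a limit of this assay, > 50000 nM, which is the limit (the limit of > 50000 nM in this assay, at which 1 of the 3 values shown sits). That means the step of an at least 3.9-fold higher number from compound 1 to compound 2 (0.59 log units; beyond the scatter) is a loss of potency of at least modest size. Compound 3 `COc1ccc(-c2noc(-c3cc4cc(OC)ccc4[nH]3)n2)cc1` differs from compound 1 by methoxy in place of chloro on an aromatic carbon, and the step of a 2.2-fold higher number from compound 1 to compound 3 (0.34 log units; beyond the scatter) weakens the activity modestly; in this assay compound 3 gives 28300 nM.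

Compound 4 `COc1ccc(-c2noc(-c3cc4cc(F)ccc4[nH]3)n2)cc1` has not yet been measured. Among the compounds with values here, its relation to compound 3 is fluoro in place of methoxy on an aromatic carbon, exactly the same change, at the same place on the core, as the one that turned compound 1 into compound 2. Since the two changes match word for word in what leaves, what enters and where it sits, the same kind of loss is expected. The expected step is a 3.2-fold higher number from compound 3 to compound 4 (0.50 log units; beyond the scatter), resting on the measured step of an at least 3.9-fold higher number from compound 1 to compound 2 (0.59 log units; beyond the scatter) applied to the weaker starting point of compound 3. Because compound 3 already gives 28300 nM, such a step would likely carry compound 4 past the range the assay reports as a number. For compound 4 the estimate in this assay is therefore 90000 nM, with a range from 30000 nM to 250000 nM, and a real chance that only a limit is recorded.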

Compound 4, half-maximal inhibitory concentration: 14800 nM
Beside the measured number, compound 4's estimate is 6.1-fold (0.78 log units) above it; the measured number lies below the stated range.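

In this assay, fluoro in place of methoxy does not carry over from one core to the other: where chloro sits on the far ring the change costs potency, but where methoxy sits there the step is a 1.9-fold lower number from compound 3 to compound 4 (0.28 log units; within the scatter), which cannot be told apart from no change, and the two steps differ clearly: the same change on two cores in this assay, an at least 3.9-fold higher number (0.59 log units; beyond the scatter) from compound 1 to compound 2 and a 1.9-fold lower number (0.28 log units; within the scatter) from compound 3 to compound 4, at least 7.4-fold (0.87 log units) apart, beyond the scatter of two such steps

The second change, methoxy in place of chloro, does not carry over either, and here the value of compound 2 is a limit of the assay and not a number, so the step of an at least 3.3-fold lower number from compound 2 to compound 4 (0.52 log units; beyond the scatter) gives only a bound on its size, yet the comparison still holds: the same change on two cores in this assay, a 2.2-fold higher number (0.34 log units; beyond the scatter) from compound 1 to compound 3 and an at least 3.3-fold lower number (0.52 log units; beyond the scatter) from compound 2 to compound 4, at least 7.4-fold (0.87 log units) apart, beyond the scatter of two such steps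

So in these four compounds the result of a change at one place depends on which group stands at the other, but this does not show why, and with only two cores it gives no rule for predicting a further pair.

The compounds shown carry only methoxy, fluoro and chloro at these places. As far as these compounds go, how an amine, a carboxylic acid or a longer chain such as butoxy would behave at either place, and whether the same dependence would appear with them, stays open.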